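The source may hold more compounds than are shown below. What is called first, only, known or untested is meant among the compounds shown, and "the series" means these compounds.

In a toxicity assay on L02 cells (Homo sapiens) for cytotoxicity, read by MTT assay, with a stated time of 72 h (a higher number here means a weaker inhibitor, a lower number a stronger inhibitor), compound 3 `CN1CCN(CCCCCCn2c3c(c4ccccc42)C(=O)c2c[n+]([O-])c4ccccc4c2C3=O)CC1` stands highest at 3800 nM while compound 1 `O=C1c2c[n+]([O-])c3ccccc3c2C(=O)c2c1c1ccccc1n2CCCCN1CCNCC1` reads 1380 nM and compound 2 `O=C1c2c[n+]([O-])c3ccccc3c2C(=O)c2c1c1ccccc1n2CCCCN1CCCCC1` reads 610 nM on the same scale. Compound 4 `CN1CCN(CCCCCn2c3c(c4ccccc42)C(=O)c2c[n+]([O-])c4ccccc4c2C3=O)CC1` has not been measured yet. It differs from compound 3 by one change (4-methylpiperazin-1-yl in place of (4-methylpiperazin-1-yl)methyl on a saturated chain carbon, five bonds along the chain from an aromatic nitrogen) that puts 4-methylpiperazin-1-yl in place of (4-methylpiperazin-1-yl)methyl on a saturated chain carbon, five bonds along the chain from an aromatic nitrogen.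

For the measured compounds named here, no measured step isolates this change. The closest is a 2.8-fold higher number from compound 1 to compound 3 (0.44 log units; beyond the scatter) with 2-(4-methylpiperazin-1-yl)ethyl in place of piperazin-1-yl, and the larger 6.2-fold higher number from compound 2 to compound 3 (0.79 log units; beyond the scatter) ends at the same compound. Compound 4 takes back only part of the chain added in a 2.8-fold higher number from compound 1 to compound 3 (0.44 log units; beyond the scatter) so a lower number than that of compound 3 is expected, though perhaps not one that clears the scatter. The expected step is a 1.6-fold lower number from compound 3 to compound 4 (0.20 log units; within the scatter) in this assay and it is a small one. The estimate for compound 4 is 2400 nM with an expected range from 1200 nM to 4800 nM in this test.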

Compound 4, half-maximal inhibitory concentration: 1640 nM
Beside the measured number, compound 4's estimate is 1.5-fold (0.17 log units) above it; the range from low to high includes it.
By their numbers in this assay, from the lowest: compound 2; then compounds 1 and 4 (each within the scatter of the next); then compound 3.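

In this assay, putting 4-methylpiperazin-1-yl in place of (4-methylpiperazin-1-yl)methyl shortens the chain and gives a 2.3-fold lower number from compound 3 to compound 4 (0.36 log units; beyond the scatter), so chain length alone can move this reading beyond the scatter. At this shorter length, a 1.2-fold higher number from compound 1 to compound 4 (0.07 log units; within the scatter) lies within the scatter, and the gap that separated compound 1 from compound 3 is no longer seen. The piperidin-1-yl end group keeps its lead, however, with a 2.7-fold higher number from compound 2 to compound 4 (0.43 log units; beyond the scatter) still beyond the scatter, and compound 2 has the lowest number of the four.

From the compounds shown here alone, how a morpholin-4-yl group or a still longer chain carrying piperidin-1-yl would read in this assay remains open. Nothing given here explains why the numbers shift with either the chain or the end group.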